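Furan-2-yl for Thiophen-3-yl on a Shared Core

The source may hold more compounds than are shown below. What is called first, only, known or untested is meant among the compounds shown, and "the series" means these compounds.

Measured compounds:
compound 1 `Oc1ccc(-c2cc(-c3ccccc3)cc(-c3ccsc3)n2)cc1`: 20.4%
compound 2 `Oc1ccc(-c2cc(-c3ccccc3)cc(-c3ccco3)n2)cc1`: 18.6%
compound 3 `Oc1cccc(-c2cc(-c3ccccc3)nc(-c3ccsc3)c2)c1`: 6.9%

Of the compounds shown here, three have been tested in an assay on isolated protein for inhibition of DNA topoisomerase 1 (Homo sapiens), with a stated time of 30 min, tested at 100 uM; a higher number here means a stronger effect of the compound at the concentration tested, a lower number a weaker effect. Compound 1 gives 20.4%, compound 2 gives 18.6%, and compound 3 gives 6.9%. Compound 1 and compound 2 differ in one place, (furan-2-yl in place of thiophen-3-yl on an aromatic carbon), and the resulting step is a number 1.8 percentage points lower from compound 1 to compound 2 (within the scatter). Compound 3 has the same atoms as compound 1, joined differently; the difference between the two cores is not broken down here. Compound 3 stands lowest of the three: compound 2 sits nearest to it with a number beyond the scatter above it, and compound 1 lies further above it, also beyond the scatter.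

Compound 4 `Oc1cccc(-c2cc(-c3ccccc3)nc(-c3ccco3)c2)c1` has not yet been measured. Relative to compound 3 it carries furan-2-yl in place of thiophen-3-yl on an aromatic carbon. This is the same kind of change as that from compound 1 to compound 2, but the surroundings of the place differ: in compound 1 the position is meta to a 4-hydroxyphenyl group, whereas in compound 3 it is meta to a 3-hydroxyphenyl group. Because the step of a number 1.8 percentage points lower from compound 1 to compound 2 (within the scatter) was within the scatter, the corresponding step is expected to be small as well, estimated as a number 0.9 percentage points lower from compound 3 to compound 4 (within the scatter) in this assay. Compound 4 is therefore expected to give about 6%, most likely between 0% and 16%.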

Compound 4, a percentage reported as inhibition, at one concentration (the size of the read-out at that concentration, not a potency): 48.8%
Compound 4: the middle estimate sits 42.8 percentage points below what was measured; measured number above the stated range.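

In this assay, furan-2-yl in place of thiophen-3-yl on the core of compound 3 gives a number 41.9 percentage points higher from compound 3 to compound 4 (beyond the scatter), so a change that did almost nothing on the core of compound 1 is large here. Within the data shown here, the change therefore does not carry over from one core to the other with a constant size, and a step read on one core cannot stand in for the step on the other: the same change on two cores in this assay, a number 1.8 percentage points lower (within the scatter) from compound 1 to compound 2 and a number 41.9 percentage points higher (beyond the scatter) from compound 3 to compound 4, 43.7 percentage points apart, beyond the scatter of two such steps What this does not show is why the two cores respond differently, since only two matched pairs are at hand, each read at a single concentration, and they say nothing about which feature of either core, or of either five-membered ring, is responsible.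

The compounds shown leave open whether the gain on the core of compound 3 belongs to furan-2-yl alone or would also appear with thiophen-2-yl or furan-3-yl, which would separate the identity of the ring hetero atom from the way the ring is attached. They also leave open whether the step survives when the hydroxyl of the 3-hydroxyphenyl group gives way to a methoxy group or an amine.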